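The source may hold more compounds than are shown below. What is called first, only, known or untested is meant among the compounds shown, and "the series" means these compounds.

Measured so far in a functional assay on A549 cells (Homo sapiens) for cytotoxicity, read by MTT assay, with a stated time of 24 h; on this read-out lower numbers stand for stronger inhibition and higher numbers for weaker inhibition:
- Compound 1 `C/C(=N\NC(=O)/C(C#N)=C/c1ccccc1)c1c(O)c2ccc(O)cc2oc1=O` gives 14800 nM
- Compound 2 `C/C(=N\NC(=O)/C(C#N)=C/c1ccc(N(C)C)cc1)c1c(O)c2ccc(O)cc2oc1=O` gives 4310 nM
- Compound 3 `C/C(=N\NC(=O)/C(C#N)=C/c1cccc([N+](=O)[O-])c1)c1c(O)c2ccc(O)cc2oc1=O` gives 21900 nM

In this assay compound 3 lies within the scatter of compound 1, while compound 2 stands apart, with a 5.1-fold higher number from compound 2 to compound 3 (0.71 log units; beyond the scatter) on record. Compound 4 `C/C(=N\NC(=O)/C(C#N)=C/c1cccc(Br)c1)c1c(O)c2ccc(O)cc2oc1=O` has not yet been measured. It carries bromo in place of nitro on an aromatic carbon, a difference that counts as bromo in place of nitro on an aromatic carbon and leaves the rest of the structure unchanged.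

Going by the values given here, no measured step exchanges these two groups directly. The nearest evidence is the entry of nitro in place of hydrogen, with a 1.5-fold higher number from compound 1 to compound 3 (0.17 log units; within the scatter) staying within the scatter. The dimethylamino step, a 3.4-fold lower number from compound 1 to compound 2 (0.54 log units; beyond the scatter) in size, did go beyond the scatter, but it concerns a very different group and says little here. No step beyond the scatter is therefore expected in this assay, only a slight drift towards compound 1. The estimated move is a 1.4-fold lower number from compound 3 to compound 4 (0.14 log units; within the scatter) at most modest in size. Compound 4 is expected near 16000 nM with an estimated range from 7000 nM to 32000 nM in this read-out.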

Compound 4, half-maximal inhibitory concentration: 22200 nM
Compound 4: the middle estimate sits 1.4-fold (0.14 log units) below what was measured, and the stated range covers the measured number.
By their numbers in this assay, from the lowest: compound 2; then compounds 1, 3 and 4 (each within the scatter of the next).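

In this assay, bromo in place of nitro on an aromatic carbon, meta to a large group, gives no readable change (a 1.0-fold higher number from compound 3 to compound 4 (0.01 log units; within the scatter)), although bromo has none of the hydrogen-bond acceptors that nitro brings. Bromo in place of hydrogen also stays within the scatter (a 1.5-fold higher number from compound 1 to compound 4 (0.18 log units; within the scatter)), so two quite different groups at this place now leave the number level with the unsubstituted phenyl of compound 1, while compound 2 with its 4-(dimethylamino)phenyl remains apart (a 5.2-fold higher number from compound 2 to compound 4 (0.71 log units; beyond the scatter)). No supporting data bear on why this place tolerates the exchange so evenly.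

The compounds shown leave open whether the lower number of compound 2 belongs to dimethylamino itself or to where it sits on the ring. They also leave open whether a methoxy group or a primary amine at the place of bromo would stay with compounds 1, 3 and 4 or move towards compound 2.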